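This account rests on a few compounds, and the source may have more. Where it says the series, first, only, none or still open, it means among the compounds named here.

In a functional assay on MCF7 cells (Homo sapiens) for inhibition, read by MTT assay, with a stated time of 72 h (a higher number here means a weaker inhibitor, a lower number a stronger inhibitor), compound 1 `COc1ccc(C(=O)/C=C/c2cc(OC)c(OC)cc2OC)cc1` gives 33900 nM and compound 2 `COc1cc(OC)c(OC)cc1/C=C/C(=O)c1ccc(F)cc1` gives 30000 nM. Swapping their groups makes little difference: a 1.1-fold lower number from compound 1 to compound 2 (0.05 log units; within the scatter). Compound 3 `COc1cc(OC)c(OC)cc1/C=C/C(=O)c1cc(O)ccc1O` is reported only as a limit, > 150000 nM. Placing its 2,5-dihydroxyphenyl on the shared core costs activity, as an at least 4.4-fold higher number from compound 1 to compound 3 (0.64 log units; beyond the scatter) and an at least 5.0-fold higher number from compound 2 to compound 3 (0.69 log units; beyond the scatter) show. Compound 4 `COc1cc(OC)c(OC)cc1/C=C/C(=O)c1ccc(O)cc1` has 4-hydroxyphenyl in place of 2,5-dihydroxyphenyl on a carbonyl carbon. This new group resembles the 4-methoxyphenyl of compound 1 and the 4-fluorophenyl of compound 2, so a return towards their values is expected. The expected change in this assay is an at least 3.3-fold lower number from compound 3 to compound 4 (0.52 log units; beyond the scatter). For compound 4 the estimated value is 45000 nM, with an expected range from 18000 nM to 120000 nM.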

Compound 4, half-maximal inhibitory concentration: 182000 nM
Compound 4: middle estimate off by 4.0-fold (0.61 log units), on the low side; measured number above the stated range.
By their numbers in this assay, from the lowest: compounds 2 and 1 (each within the scatter of the next); then compound 4.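

On this carbonyl carbon, 4-hydroxyphenyl does not behave like the 4-fluorophenyl or the 4-methoxyphenyl: hydroxy in place of fluoro gives a 6.1-fold higher number from compound 2 to compound 4 (0.78 log units; beyond the scatter), and removing the methyl from the oxygen gives a 5.4-fold higher number from compound 1 to compound 4 (0.73 log units; beyond the scatter). Both compounds that carry a free hydroxy, compound 3 and compound 4, are therefore weak, so the second hydroxy of compound 3 is not needed for weak activity. How compound 4 compares with compound 3 cannot be read because compound 3 is reported only as a limit: the limit of > 150000 nM in this assay, at which 1 of the 4 values shown sits.

Still open, on these data alone, is whether an amine or a carboxylic acid on this ring would follow the hydroxy or the fluoro and methoxy.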